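This account rests on a few compounds, and the source may have more. Where it says the series, first, only, none or still open, it means among the compounds named here.

Compound 1 `O=C(Nc1cccnc1)c1cccnc1`: 3%
Compound 2 `O=C(Nc1cccnc1)c1ccncc1`: 4%
Compound 3 `O=C(Nc1cccnc1)c1ccccc1`: 2%

All three were tested in an assay on V79 cells for inhibition of cytochrome P450 11B1, mitochondrial (Homo sapiens), tested at 500 nM; on this read-out lower numbers stand for less inhibition and higher numbers for more inhibition at the one concentration tested (going by the name of the read-out). Compound 3 holds the lowest of the three numbers, its nearest being compound 1 and its furthest compound 2, yet both gaps fall within the scatter of repeated measurements, so the three cannot be told apart on this read-out. The step onward leads to compound 4 `O=C(Nc1cccnc1)c1ccc(Cl)cc1`, which differs from compound 3 as follows: chloro in place of hydrogen on an aromatic carbon. Within the data shown here, no measured pair shows a change of this kind, so there is nothing to set the step against. With all known values sitting near the bottom of the scale, compound 4 is expected to stay close to them, with at most a small rise that need not exceed the scatter, an expected step of a number 6 percentage points higher from compound 3 to compound 4 (within the scatter). Compound 4 is therefore estimated at 8%, within a range from 0% to 25%.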

Compound 4, a percentage reported as inhibition, at one concentration (the size of the read-out at that concentration, not a potency): 5%
For compound 4 the middle estimate is 3 percentage points above the measured one; measured number inside the range.
By their numbers in this assay, from the lowest: compounds 3, 1, 2 and 4 (each within the scatter of the next).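

In this assay chloro in place of hydrogen on an aromatic carbon, para to a group of 9 heavy atoms, gives a number 3 percentage points higher from compound 3 to compound 4 (within the scatter) and so leaves compound 3 and compound 4 indistinguishable. Among these compounds, this is the first substituent on that ring to be read here, and a single chlorine at this position does not lift the compound clear of the others. Nothing available here bears on the reason for this result. On these data alone, whether an amine, a carboxylic acid or a longer chain on the same carbon would stand clear of the scatter remains open. So does the outcome of chloro on the pyridine-free ring's other carbons.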